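The source may report more compounds than this note shows. Statements on the series, on what has been measured and on what is new or still open speak of the compounds shown alone.

The measured compounds:

Compound 1 `CCc1ccc(S(=O)(=O)N2CCC(N3CCC(C)CC3)CC2)cc1`: in an ADME assay on HCT-116 cells (Homo sapiens) for cytotoxicity, read by CellTiter-Glo, with a stated time of 72 h (on this read-out lower numbers stand for stronger inhibition and higher numbers for weaker inhibition), compound 1 gives only a limit, > 5000 nM.

Compound 2 `CC1CCN(C2CCN(S(=O)(=O)c3ccc(F)cc3F)CC2)CC1`: in this assay compound 2 gives only a limit, > 5000 nM.

Compound 3 `CC1CCN(C2CCN(S(=O)(=O)c3nccn3C)CC2)CC1`: in this assay compound 3 gives only a limit, > 10000 nM.

Compound 1 therefore stands at a limit rather than a number, and the two other values are limits as well, as the limit of > 5000 nM in this assay, at which 2 of the 3 values shown sit, and the limit of > 10000 nM in this assay, at which 1 of the 3 values shown sits, record. The steps from compound 1 to compound 2 a step that the two limits leave unreadable from compound 1 to compound 2 and from compound 1 to compound 3 a step that the two limits leave unreadable from compound 1 to compound 3 cannot be read in size, and the same holds for a step that the two limits leave unreadable from compound 2 to compound 3.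

Compound 4 `COC(=O)c1ccc(S(=O)(=O)N2CCC(N3CCC(C)CC3)CC2)cc1` differs from compound 1 in one place: methoxycarbonyl in place of ethyl on an aromatic carbon. Ethyl leaves and methoxycarbonyl enters, on an aromatic carbon of the six-membered carbon-only ring of the shared core.

Among the measured compounds shown here, no measured step bears a readable size on this change; each exchange on the sulfonyl sulfur left the value at a limit. Compound 4 is therefore expected to give another limit, with an expected step that the limit leaves unreadable from compound 1 to compound 4 that would not be readable. The estimate for compound 4 is 8000 nM, between 3000 nM and 30000 nM.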

Compound 4, half-maximal inhibitory concentration: > 5000 nM
Compound 4: no number, only a limit; the forecaster's own chance of this, stated with the estimate: 85%; the middle value lies beyond the limit too.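

Compound 1 and compound 4 both stand at a limit in this assay, so the step between them cannot be read in size: the limit of > 5000 nM in this assay, at which 3 of the 4 values shown sit.

The compounds shown give only limits and leave open whether any of these exchanges changes the value in this assay at all.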